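Swapping the outer ring substituent on a boron-containing anilide

The source may hold more compounds than are shown below. What is called first, only, known or untested is meant among the compounds shown, and "the series" means these compounds.

Two measured compounds share a core and an amide linker. Compound 1 `O=C(CCc1cccc2c1B(O)OC2)Nc1ccc([N+](=O)[O-])cc1` carries a nitrophenyl on the amide nitrogen, and in a functional assay on MDA-MB-231 cells (Homo sapiens) for antiproliferative activity, read by MTT assay, with a stated time of 72 h (a higher number here means a weaker inhibitor, a lower number a stronger inhibitor), compound 1 gives 36000 nM. Compound 2 `O=C(CCc1cccc2c1B(O)OC2)Nc1cccc(-c2cccc(F)c2)c1` instead carries a biphenyl bearing a fluorine, and in this assay compound 2 gives 570 nM, the lower of the two numbers by a margin that lies well beyond the usual scatter.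

Compound 3 `N#Cc1ccc(-c2cccc(NC(=O)CCc3cccc4c3B(O)OC4)c2)cc1` keeps everything of compound 2 except the outer ring: 4-cyanophenyl in place of 3-fluorophenyl on an aromatic carbon. Among the compounds with values here, no measured pair shows the effect of such a swap, so the expectation rests on compound 2 alone. The step from compound 2 to compound 3 is expected to be small, a 1.4-fold higher number from compound 2 to compound 3 (0.15 log units; within the scatter), probably toward a slightly higher number but not clearly beyond the scatter. Compound 3 is therefore estimated at 800 nM, with a likely range from 250 nM to 2500 nM.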

Compound 3, half-maximal inhibitory concentration: 380 nM
The estimate for compound 3 lay 2.1-fold (0.32 log units) above the measured number, within the range that was stated.
By their numbers in this assay, from the lowest: compounds 3 and 2 (each within the scatter of the next); then compound 1.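

In this assay, the change to 4-cyanophenyl in place of 3-fluorophenyl gives a 1.5-fold lower number from compound 2 to compound 3 (0.18 log units; within the scatter) on this aromatic carbon, so the two compounds cannot be told apart. This outer ring can therefore accept a different substituent, here a nitrile with its hydrogen-bond acceptor in place of a fluorine, with no clear change in the number. No supporting measurement is available to explain this result.

Because the substituent and its place on the outer ring change together, this pair cannot separate the effect of one from the other. Going by these compounds, it also remains open whether an outer ring bearing an amine or a carboxylic acid would stay in the same range, and whether a longer chain between the core and the amide would do so.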